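Amide series: piperidinyl for propylamino on the aminopyridine side

The source may report more compounds than this note shows. Statements on the series, on what has been measured and on what is new or still open speak of the compounds shown alone.

Within the data shown here, the two measured members are compound 2 `CCCNc1cccc(NC(=O)c2ccc(OCCC)cc2)n1` and compound 1 `C#CCOc1ccc(C(=O)Nc2cccc(C)n2)cc1`. In an in vitro assay on HEK-tsA201 cells for antagonist activity at Neuronal acetylcholine receptor; alpha4/beta2 (Homo sapiens), read by fluorescence and calcium flux (on this read-out lower numbers stand for stronger inhibition and higher numbers for weaker inhibition), compound 2 gives 15400 nM, and compound 1 gives 19400 nM; the two values lie within the scatter of each other, so neither is set apart. Compound 3 `CCCOc1ccc(C(=O)Nc2cccc(N3CCCCC3)n2)cc1` has not been measured. It differs from compound 2 by piperidin-1-yl in place of propylamino on an aromatic carbon. Among the measured compounds shown here, no step between measured compounds bears on this change, so no more than scatter is expected: the step from compound 2 to compound 3 is estimated at a 1.0-fold higher number from compound 2 to compound 3 (0.02 log units; within the scatter). Compound 3 is expected to give 16000 nM, within 5000 nM to 50000 nM.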

Compound 3, half-maximal inhibitory concentration: > 100000 nM
Compound 3 ended at the assay's limit; the forecaster's own chance of this, stated with the estimate: 20%; middle value at least 6.2-fold (0.79 log units) from the limit.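

On this position the series is not indifferent to the change: piperidin-1-yl in place of propylamino, next to the ring nitrogen, gives an at least 6.4-fold higher number from compound 2 to compound 3 (0.81 log units; beyond the scatter). The swap both removes the hydrogen-bond donor and closes a six-membered non-aromatic ring, and this single step does not separate the two. Compound 3 stands at a limit in this assay, so the size of the step is only a bound: the limit of > 100000 nM in this assay, at which 1 of the 3 values shown sits.

Open, on these data alone, is whether the loss of inhibition follows the ring or the missing donor. A dimethylamino group and a cyclohexylamino group would bear on that question.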